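This account rests on a few compounds, and the source may have more. Where it says the series, first, only, none or still open, it means among the compounds named here.

Measured so far in an ADME assay on microsomes from liver (Rattus norvegicus) for metabolic stability, read by LC-MS, using NADPH; on this read-out lower numbers stand for a shorter-lived compound and higher numbers for a longer-lived compound:
- compound 1 `O=C(NCCCCN1CCN(c2cccc(Cl)c2)CC1)c1ccc(-c2ccsc2)cc1` gives 0.468 h
- compound 2 `O=C(NCCCCN1CCN(c2cccc(O)c2)CC1)c1ccc(-c2ccsc2)cc1` gives 0.085 h
- compound 3 `Cc1ccc(N2CCN(CCCCNC(=O)c3ccc(-c4ccsc4)cc3)CC2)cc1` gives 0.125 h

Compound 2 has the lowest of the three numbers. Its nearest neighbour is compound 3, with a 1.5-fold higher number from compound 2 to compound 3 (0.17 log units; within the scatter), a gap that stays within the scatter. The furthest is compound 1, reached by a 5.5-fold lower number from compound 1 to compound 2 (0.74 log units; beyond the scatter), which is beyond the scatter.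

Compound 4 `N#Cc1ccc(N2CCN(CCCCNC(=O)c3ccc(-c4ccsc4)cc3)CC2)cc1` differs from compound 2 in one place: 4-cyanophenyl in place of 3-hydroxyphenyl on an amine nitrogen in a ring. Among the compounds with values here, two measured steps bear on the exchange of the aryl group on the ring nitrogen: a 3.7-fold lower number from compound 1 to compound 3 (0.57 log units; beyond the scatter) and a 1.5-fold higher number from compound 2 to compound 3 (0.17 log units; within the scatter). Both replace the aryl group as a whole, and the two aryl groups without a hydroxy give numbers that lie no lower than compound 2 does. Within the data shown here, no measured step exchanges a hydroxy for a nitrile, so the exact size for this assay is open. A modest rise is expected, with the direction toward compound 3 and compound 1.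

For compound 4 the estimate is 0.18 h, within 0.07 h to 0.45 h, corresponding to an expected 2.1-fold higher number from compound 2 to compound 4 (0.33 log units; beyond the scatter).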

Compound 4, half-life: 0.22 h
Compound 4: the middle estimate sits 1.2-fold (0.09 log units) below what was measured, and the stated range covers the measured number.
By their numbers in this assay, from the lowest: compounds 2, 3 and 4 (each within the scatter of the next, the first and the last beyond it); then compound 1.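

In this assay, within the data shown here, 4-cyanophenyl in place of 3-hydroxyphenyl on the amine nitrogen in a ring gives a 2.6-fold higher number from compound 2 to compound 4 (0.41 log units; beyond the scatter), the first aryl group without chloro to stand clear of compound 2 beyond the scatter. Cyano in place of methyl gives a 1.8-fold higher number from compound 3 to compound 4 (0.25 log units; within the scatter), which stays within the scatter, so this read-out does not separate these two groups. The 3-chlorophenyl group keeps its lead over the nitrile, with a 2.1-fold lower number from compound 1 to compound 4 (0.33 log units; beyond the scatter), and compound 1 remains beyond the scatter of all three other compounds.

Nothing available gives a cause for these differences.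

Still open, as far as these compounds go, is how 4-chlorophenyl or 3-cyanophenyl would read, since these would separate the effect of the group from where it sits on the aryl ring.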